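Methyl in place of chloro on compound 2

The compounds below may be only part of what the source reports. "The series", "measured", "known", "first", "only" and "open" are said of these compounds alone.

Compound 1 `COc1cc(/C=C/C(=O)c2sc(Nc3ccc(Cl)cc3)nc2C)cc(OC)c1OC` gives 22000 nM in a functional assay on NCI-H460 cells (Homo sapiens) for cytotoxicity, read by MTT assay; a higher number here means a weaker inhibitor, a lower number a stronger inhibitor.
Compound 2 `Cc1nc(Nc2cccc(Cl)c2)sc1C(=O)/C=C/c1ccccc1` gives > 25000 nM, a limit of the assay rather than a number.
Compound 3 `Cc1nc(Nc2cccc(Cl)c2)sc1C(=O)/C=C/c1ccc(Cl)cc1` gives > 25000 nM, likewise a limit.

Compound 2 therefore stands at the limit of > 25000 nM in this assay, at which 2 of the 3 values shown sit, and only compound 1 yields a number at all. Going by the values given here, the one measured change touching compound 2 is a step that the two limits leave unreadable from compound 2 to compound 3, chloro in place of hydrogen on an aromatic carbon, whose size the two limits leave unreadable. Compound 4 `Cc1cccc(Nc2nc(C)c(C(=O)/C=C/c3ccccc3)s2)c1` differs from compound 2 by methyl in place of chloro on an aromatic carbon. Among the compounds with values here, no measured step reads a size, so no direction beyond the scatter can be drawn from them. Compound 4 is expected to remain weak, with an estimated 30000 nM in the range 12000 nM to 80000 nM, an expected step that the limit leaves unreadable from compound 2 to compound 4.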

Compound 4, half-maximal inhibitory concentration: 21800 nM
Compound 4: the middle estimate sits 1.4-fold (0.14 log units) above what was measured; low and high end bracket the measured number.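

Methyl in place of chloro on this aromatic carbon, meta to a large group, gives the first readable step at this position: an at least 1.1-fold lower number from compound 2 to compound 4 (0.05 log units; that floor lies within the scatter). This step is only a floor, so it shows that the 3-methylphenyl compound can be read as a number but does not fix how large the change is. Compound 2 itself remains a limit: the limit of > 25000 nM in this assay, at which 2 of the 4 values shown sit. The compounds shown leave open how far the number would move with an amine or a carboxylic acid on this carbon.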